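Bromine for methoxy on a diterpenoid butenolide

A few compounds are considered here, and "the series" means these few. Any claim that something is new, unique, unknown or untested is made for them only; others in the source may bear on it.

Measured so far:
compound 1, `C=C1CC[C@@H]2[C@](C)(COC(=O)c3cccnc3)[C@H](OC(=O)c3cccnc3)CC[C@@]2(C)[C@@H]1/C=C/C1=CCOC1=O`: "not active" (no number reported)
compound 2, `C=C1CC[C@@H]2[C@](C)(CO)[C@H](O)CC[C@@]2(C)[C@@H]1/C=C/C1=C/C(=C/c2ccc(OC)cc2)OC1=O`: 34%

Among the measured compounds shown here, in a functional assay on PC-3 cells (Homo sapiens), read by wound healing assay, with a stated time of 48 h, tested at 10 uM (on this read-out higher numbers stand for more inhibition at the one concentration tested (going by the name of the read-out) and lower numbers for less inhibition), compound 2 gives 34%, the only number in this set. Compound 1 is reported there as "not active" (no number reported), with no number attached. Compound 3, `C=C1CC[C@@H]2[C@](C)(CO)[C@H](O)CC[C@@]2(C)[C@@H]1/C=C/C1=C/C(=C/c2ccc(Br)cc2)OC1=O`, is not yet measured. It differs from compound 2 in one place, (bromo in place of methoxy on an aromatic carbon). For the measured compounds named here, no step between two measured compounds exists here to calibrate such a swap, so the expectation is a step within the scatter, a number 1 percentage points higher from compound 2 to compound 3 (within the scatter), in either direction. Compound 3 is therefore estimated at 35%, between 15% and 55%.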

Compound 3, a percentage reported as inhibition, at one concentration (the size of the read-out at that concentration, not a potency): 83.8%
Compound 3: the middle estimate sits 48.8 percentage points below what was measured; the whole stated range lies below it.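

The 4-methoxyphenyl group of compound 2 is not a fixed part of the activity: in this assay, changing it to 4-bromophenyl gives a number 49.8 percentage points higher from compound 2 to compound 3 (beyond the scatter). A single substituent on this aromatic carbon, para to a large group, can therefore change the read-out far beyond ordinary variation. Nothing available explains this gain.

With only methoxy and bromo compared at this position, the result leaves open whether chloro, nitrile or an amine would resemble either. It also leaves open whether bromo would have the same effect on another ring carbon.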